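Chromone acetamide series: aryl amide in place of propyl

A few compounds are considered here, and "the series" means these few. Any claim that something is new, unique, unknown or untested is made for them only; others in the source may bear on it.

Compound 2 `CCCC(=O)Nc1cccc(NC(=O)COc2ccc3c(=O)ccoc3c2)c1` gives 176 nM in an assay on isolated protein for inhibition of Rho-associated protein kinase 2 (Homo sapiens), read by scintillation counting, radiometric assay and 33P incorporation, with a stated time of 40 min, in the presence of a further agent that is not named here (on this read-out higher numbers stand for weaker inhibition and lower numbers for stronger inhibition), the lower of the two numbers recorded so far. Compound 1 `COc1cccc(OCC(=O)Nc2cccc(NC(=O)c3ccc(N(C)C)cc3)c2)c1` gives 5740 nM in this assay, a gap beyond the usual scatter; as the two compounds differ in more than one place, no single change explains it. Compound 3 `CC(C)(C)c1ccc(C(=O)Nc2cccc(NC(=O)COc3ccc4c(=O)ccoc4c3)c2)cc1` differs from compound 2 by 4-(tert-butyl)phenyl in place of propyl on a carbonyl carbon. Within the data shown here, with no measured step of this kind to lean on, the move from compound 2 to compound 3 is expected to be modest, a 1.7-fold higher number from compound 2 to compound 3 (0.23 log units; within the scatter), in either direction. Compound 3 is estimated at 300 nM, within 80 nM to 1200 nM.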

Compound 3, half-maximal inhibitory concentration: 34 nM
Estimate against measurement, compound 3: 8.8-fold (0.95 log units) above; the whole stated range lies above it.
By their numbers in this assay, from the lowest: compound 3; then compound 2; then compound 1.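

On the carbonyl carbon whose other neighbour is an amide-type nitrogen, the shared core accepts a much larger aromatic group than propyl: in this assay 4-(tert-butyl)phenyl in place of propyl gives a 5.2-fold lower number from compound 2 to compound 3 (0.71 log units; beyond the scatter) and inhibition is stronger, not lost. Among these compounds, this is the first single-place step, and it rests on one pair. No measurement here explains the gain.

From the compounds shown here alone, whether the ring or the tert-butyl group carries the step remains open. Plain phenyl, a longer alkyl chain or a 4-(dimethylamino)phenyl group at this carbonyl would help separate the two.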